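This account rests on a few compounds, and the source may have more. Where it says the series, first, only, none or still open, it means among the compounds named here.

Working notes on the series. Compound 1 `CCOC(=O)[C@H](CCC(=O)O)NC(=O)c1ccc(Sc2nc3cc(N)cc(N)c3nc2-c2ccccc2)cc1` gives 24500 nM in a functional assay on 786-0 cells (Homo sapiens) for inhibition, read by sulforhodamine B assay, with a stated time of 48 h; on this read-out higher numbers stand for weaker inhibition of growth and lower numbers for stronger inhibition of growth. Compound 2 `Nc1cc(N)c2nc(-c3ccccc3)c(Sc3ccc(F)cc3)nc2c1` is reported only as a limit, < 100000 nM, in this assay. Compound 3 `Nc1cc(N)c2nc(-c3ccccc3)c(Oc3ccc(F)cc3)nc2c1` gives 15500 nM in this assay, the lowest of the two numbers shown; compound 1 sits within the scatter of it. Among the compounds with values here, the only measured step, a step that the limit leaves unreadable from compound 2 to compound 3, cannot be sized because of the limit of < 100000 nM in this assay, at which 1 of the 3 values shown sits. Compound 4 `Nc1cc(N)c2nc(-c3ccccc3)c(NCc3ccc(F)cc3)nc2c1` differs from compound 3 by (4-fluorobenzyl)amino in place of 4-fluorophenoxy on an aromatic carbon. Within the data shown here, no measured step covers this change, so no direction beyond the scatter is expected, and the step of a 1.3-fold higher number from compound 3 to compound 4 (0.11 log units; within the scatter) is an estimate with wide uncertainty. Compound 4 is therefore expected to give about 20000 nM, within 5000 nM to 80000 nM, in this assay.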

Compound 4, concentration for 50% growth inhibition: 23400 nM
For compound 4 the middle estimate is 1.2-fold (0.07 log units) below the measured one; the measured number falls inside the stated range.
By their numbers in this assay, from the lowest: compounds 3, 4 and 1 (each within the scatter of the next).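

Replacing 4-fluorophenoxy with (4-fluorobenzyl)amino on this aromatic carbon next to the ring nitrogen gives a 1.5-fold higher number from compound 3 to compound 4 (0.18 log units; within the scatter) in this assay. At this position, the read-out therefore does not separate the two groups, even though only (4-fluorobenzyl)amino carries a hydrogen-bond donor. The steps from compound 2 cannot be read: the limit of < 100000 nM in this assay, at which 1 of the 4 values shown sits.

From the compounds shown here alone, whether a plain amine or a longer chain at this position would move the number beyond the scatter remains open. Also open is whether the fluorine on the benzyl ring matters, since a chlorine or hydrogen there is not among the compounds shown.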